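Adding a methoxy to compound 2

The source may hold more compounds than are shown below. What is called first, only, known or untested is meant among the compounds shown, and "the series" means these compounds.

Compound 1 `COc1ccc(/C=C2\CCC/C(=C\c3ccccc3Br)C2=O)cc1OC`: 21800 nM
Compound 2 `COc1cccc(/C=C2\CCC/C(=C\c3ccc(OC)c(OC)c3)C2=O)c1`: 11600 nM
Compound 3 `COc1ccc(/C=C2\CCC/C(=C\c3ccc(OC)c(OC)c3)C2=O)cc1`: 30900 nM

These values come from an ADME assay on NHDF cells (Homo sapiens) for cytotoxicity, read by MTT assay, with a stated time of 72 h; on this read-out higher numbers stand for weaker inhibition and lower numbers for stronger inhibition. Compound 2 holds the lowest of the three numbers, with a 1.9-fold lower number from compound 1 to compound 2 (0.27 log units; within the scatter) and a 2.7-fold higher number from compound 2 to compound 3 (0.43 log units; beyond the scatter). The remaining step, a 1.4-fold higher number from compound 1 to compound 3 (0.15 log units; within the scatter), is also small.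

Compound 4 `COc1cc(/C=C2\CCC/C(=C\c3ccc(OC)c(OC)c3)C2=O)cc(OC)c1` differs from compound 2 by methoxy in place of hydrogen on an aromatic carbon. All three measured steps exchange one substituted phenyl group for another, and none adds a group, so they bear on this change only indirectly. Their sizes give no reason to expect a large step, and both other compounds carry higher numbers than compound 2. A small rise in this assay is therefore expected, most likely not beyond the scatter. The estimated step is a 1.4-fold higher number from compound 2 to compound 4 (0.14 log units; within the scatter). For compound 4 the estimated value is 16000 nM, with an expected range of 7000 nM to 36000 nM.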

Compound 4, half-maximal inhibitory concentration: 6500 nM
The estimate for compound 4 lay 2.5-fold (0.39 log units) above the measured number; the measured number lies below the stated range.
By their numbers in this assay, from the lowest: compounds 4, 2, 1 and 3 (each within the scatter of the next, the first and the last beyond it).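

Methoxy in place of hydrogen on an aromatic carbon, meta to a large group and meta to a methoxy group, gives in this assay a 1.8-fold lower number from compound 2 to compound 4 (0.25 log units; within the scatter) and so leaves compound 4 within the scatter of compound 2. For the compounds shown here, this is the first step that adds a group instead of exchanging one substituted phenyl group for another, and at this position the added methoxy produces no change that can be told from repeat scatter. No measurement shown here bears on why this addition leaves the number within the scatter.

Going by these compounds, whether an amine or a hydroxy group at this same position would give a step beyond the scatter remains open. Also open, on these data alone, is whether the same methoxy addition on the other aromatic ring of compound 2 would give a similar step.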